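Biphenyl amide series: phenoxy in place of tert-butyl

The source may report more compounds than this note shows. Statements on the series, on what has been measured and on what is new or still open speak of the compounds shown alone.

Measured so far:
compound 1 `CC[C@H](C)[C@H](N)CN(C(=O)[C@@H]1C[C@H]1c1ccccn1)c1ccc(-c2ccccc2)cc1` — 130 nM
compound 2 `CC(C)C[C@H](N)CN(C(=O)[C@@H]1C[C@H]1c1ccccc1)c1ccc(-c2ccc(Cl)cc2)cc1` — 640 nM
compound 3 `CC[C@H](C)[C@H](N)CN(C(=O)[C@@H]1C[C@H]1c1ccccc1)c1ccc(-c2ccc(C(C)(C)C)cc2)cc1` — 750 nM

In a functional assay for agonist activity at G protein-coupled receptor 88 (Homo sapiens), read by HTRF and cAMP accumulation (on this read-out lower numbers stand for an effect already at smaller amounts and higher numbers for an effect only at larger amounts of compound), compound 3 gives the highest of the three numbers. Its number sits within the scatter of that of compound 2, so the two cannot be ordered; compound 1 lies beyond the scatter from compound 3, at a lower number.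

Compound 4 `CC[C@H](C)[C@H](N)CN(C(=O)[C@@H]1C[C@H]1c1ccccc1)c1ccc(-c2ccc(Oc3ccccc3)cc2)cc1` differs from compound 3 by phenoxy in place of tert-butyl on an aromatic carbon, a phenoxy in place of tert-butyl on an aromatic carbon. For the measured compounds named here, no pair of measured compounds shows this change, so the step has no precedent. The step of a 1.1-fold higher number from compound 3 to compound 4 (0.03 log units; within the scatter) is expected to stay within the scatter, with no clear direction. Compound 4 is therefore estimated at 800 nM, with a range from 250 nM to 2500 nM.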

Compound 4, half-maximal effective concentration: 94 nM
Beside the measured number, compound 4's estimate is 8.5-fold (0.93 log units) above it; measured number below the stated range.
By their numbers in this assay, from the lowest: compounds 4 and 1 (each within the scatter of the next); then compounds 2 and 3 (each within the scatter of the next).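

In this assay, phenoxy in place of tert-butyl on an aromatic carbon gives an 8.0-fold lower number from compound 3 to compound 4 (0.90 log units; beyond the scatter) in the first single-change comparison available in the series. This position, para to a large group, therefore affects the read-out, and the larger group with its aromatic ring and hydrogen-bond acceptor is tolerated. Nothing measured here accounts for the step.

As far as these compounds go, whether the oxygen or the added ring matters more remains open; a phenyl or benzyl group at this carbon would help separate them. From the compounds shown here alone, whether the step carries over to the core of compound 1 also remains open.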